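Series notes: from methoxy to bromo

The source may report more compounds than this note shows. Statements on the series, on what has been measured and on what is new or still open speak of the compounds shown alone.

Measured in a functional assay on A-431 cells (Homo sapiens) for inhibition, read by MTT assay, with a stated time of 72 h; a higher number here means a weaker inhibitor, a lower number a stronger inhibitor:
- compound 1 `COc1ccc(-c2nnc(SCCCN3CCN(c4nc5ccccc5o4)CC3)o2)cc1`: 52700 nM
- compound 2 `COc1ccc(-c2nnc(SCCCN3CCN(c4nc5ccccc5s4)CC3)o2)cc1`: 56200 nM

Compound 2 gives 56200 nM and lies within the scatter of compound 1 at 52700 nM. Compound 3 `Brc1ccc(-c2nnc(SCCCN3CCN(c4nc5ccccc5s4)CC3)o2)cc1` carries bromo in place of methoxy on an aromatic carbon, para to a large group: bromo in place of methoxy on an aromatic carbon. Among the compounds with values here, the only measured step, a 1.1-fold higher number from compound 1 to compound 2 (0.03 log units; within the scatter), is 1,3-benzothiazol-2-yl in place of 1,3-benzoxazol-2-yl and stays within the scatter. Within the data shown here, no measured step touches the 4-methoxyphenyl group, so the data give no direction for this change. No step beyond the scatter is expected in this assay, though the range is kept wide. Compound 3 is estimated at 45000 nM, with an expected range of 18000 nM to 100000 nM. The estimated step is a 1.2-fold lower number from compound 2 to compound 3 (0.10 log units; within the scatter).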

Compound 3, half-maximal inhibitory concentration: 51600 nM
Compound 3: middle estimate off by 1.1-fold (0.06 log units), on the low side; the range from low to high includes it.
By their numbers in this assay, from the lowest: compounds 3, 1 and 2 (each within the scatter of the next).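

In this assay, within the data shown here, the change from 4-methoxyphenyl to 4-bromophenyl, the first measured change at this position, gives a 1.1-fold lower number from compound 2 to compound 3 (0.04 log units; within the scatter). With 1,3-benzothiazol-2-yl held constant, methoxy and bromo therefore cannot be told apart at this position in this assay. Bromo in place of methoxy thus joins 1,3-benzothiazol-2-yl in place of 1,3-benzoxazol-2-yl as a second single change that stays within the scatter, and no available measurement offers an explanation for this result.

From the compounds shown here alone, whether an amine or a carboxylic acid on this aromatic carbon would move the number beyond the scatter remains open. Also open, going by these compounds, is whether bromo in place of methoxy would read the same with 1,3-benzoxazol-2-yl in place of 1,3-benzothiazol-2-yl.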